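Benzyl substitution on the hydrazone arm: expectation for compound 4

The compounds below may be only part of what the source reports. "The series", "measured", "known", "first", "only" and "open" are said of these compounds alone.

Compound 1 `Cc1cccc(NC2=C/C(=N/NC(N)=S)C(=O)N=C2Nc2cccc(C)c2)c1` and compound 2 `Cc1ccc(NC2=C/C(=N/NC(N)=S)C(=O)N=C2Nc2ccc(C)cc2)cc1` are built from the same atoms joined differently; how the two cores differ is not broken down here. In a functional assay on HCT-116 cells (Homo sapiens) for antiproliferative activity, read by MTT assay, with a stated time of 72 h (on this read-out lower numbers stand for stronger inhibition and higher numbers for weaker inhibition), compound 1 gives 8650 nM, and compound 2 gives 7040 nM, the two numbers lying within the scatter of each other. Compound 3 `Cc1cccc(NC2=C/C(=N/N=C(\N)SCc3ccccc3)C(=O)N=C2Nc2cccc(C)c2)c1` carries a group of 11 heavy atoms (8 carbon, 2 nitrogen, 1 sulfur; one six-membered aromatic ring of carbon only) in place of a group of 4 heavy atoms (1 carbon, 2 nitrogen, 1 sulfur; no ring), on a double-bonded nitrogen relative to compound 1. In this assay compound 3 gives 12900 nM, so that the step of a 1.5-fold higher number from compound 1 to compound 3 (0.17 log units; within the scatter). Compound 4 `Cc1ccc(NC2=C/C(=N/N=C(\N)SCc3ccccc3)C(=O)N=C2Nc2ccc(C)cc2)cc1` is not yet measured; it carries a group of 11 heavy atoms (8 carbon, 2 nitrogen, 1 sulfur; one six-membered aromatic ring of carbon only) in place of a group of 4 heavy atoms (1 carbon, 2 nitrogen, 1 sulfur; no ring), on a double-bonded nitrogen relative to compound 2, the same change at the same place. The expectation for compound 4 rests on the step of a 1.5-fold higher number from compound 1 to compound 3 (0.17 log units; within the scatter) and on compound 2 giving 7040 nM. For compound 4 in this assay a step of a 1.5-fold higher number from compound 2 to compound 4 (0.17 log units; within the scatter) is expected. Compound 4 is therefore estimated at 10500 nM, expected between 4500 nM and 25000 nM.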

Compound 4, half-maximal inhibitory concentration: 8270 nM
For compound 4 the middle estimate is 1.3-fold (0.10 log units) above the measured one; low and high end bracket the measured number.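

In this assay the new step is a 1.2-fold higher number from compound 2 to compound 4 (0.07 log units; within the scatter). Set beside the earlier step, the exchange of the group of 4 heavy atoms for the group of 11 heavy atoms carries from one core to the other without a readable difference: the same change on two cores in this assay, a 1.5-fold higher number (0.17 log units; within the scatter) from compound 1 to compound 3 and a 1.2-fold higher number (0.07 log units; within the scatter) from compound 2 to compound 4, 1.3-fold (0.10 log units) apart, within the scatter of two such steps

Both steps lie within the scatter, so the two cores agree only in showing no readable effect of this change; this does not show that the change would be equally silent on any other core or in any other assay.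

Open, from the compounds shown here alone, is whether a different group at this place, such as an amine, a carboxylic acid or a longer chain, would give a step beyond the scatter. Also open, going by these compounds, is how the change behaves on a core carrying something other than the methyl groups.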